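The source may report more compounds than this note shows. Statements on the series, on what has been measured and on what is new or still open speak of the compounds shown alone.

Working notes on the series. In a functional assay on B16-F10 cells (Mus musculus) for antiproliferative activity, read by MTT assay, with a stated time of 48 h (on this read-out lower numbers stand for stronger inhibition and higher numbers for weaker inhibition), compound 1 (`Cc1ccc(NCc2cn(-c3ccccc3)nc2-c2ccc(Cl)cc2)cc1`) gives 3480 nM and compound 2 (`Brc1ccc(NCc2cn(-c3ccccc3)nc2-c2ccc(Br)cc2)cc1`) gives 5270 nM so compound 2 stands within the scatter of compound 1. For the measured compounds named here, no step between measured compounds that differ in one place is available yet, so any expectation rests on these two values alone. Compound 3 (`Cc1ccc(NCc2cn(-c3ccccc3)nc2-c2ccc(Br)cc2)cc1`) arises from compound 2 with methyl in place of bromo on an aromatic carbon, para to a large group (methyl in place of bromo on an aromatic carbon). Compound 1 carries the same (4-methylphenyl)amino group and gives 3480 nM so no step beyond the scatter is expected in this assay and any drift would more likely be toward a slightly lower number. The estimated 1.3-fold lower number from compound 2 to compound 3 (0.12 log units; within the scatter) is therefore expected to stay within the scatter. For compound 3 the expected value is 4000 nM (estimated range 1900 nM to 8500 nM).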

Compound 3, half-maximal inhibitory concentration: 5980 nM
Compound 3: middle estimate off by 1.5-fold (0.17 log units), on the low side; low and high end bracket the measured number.
By their numbers in this assay, from the lowest: compounds 1, 2 and 3 (each within the scatter of the next).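

In this assay, replacing bromo with methyl on an aromatic carbon, para to a large group, gives the first step read at this position: a 1.1-fold higher number from compound 2 to compound 3 (0.05 log units; within the scatter) and so within the scatter. Bromo in place of chloro on an aromatic carbon gives a 1.7-fold higher number from compound 1 to compound 3 (0.24 log units; within the scatter) and also stays within the scatter, so neither single change separates these compounds. Nothing measured here speaks to the reason for these values.

The compounds shown leave open whether this position responds at all to a group unlike bromo and methyl, such as an amine or a carboxylic acid. They also leave open whether a step beyond the scatter can be reached by replacing the chloro or bromo of the other substituted aromatic ring with a methoxy group.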